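A few compounds are considered here, and "the series" means these few. Any claim that something is new, unique, unknown or untested is made for them only; others in the source may bear on it.

Measured compounds:
Compound 1, `O=C(/C=C/c1ccc(OCc2nc(C3CCN(Cc4ccccc4)CC3)no2)cc1)NO`: in an assay on isolated protein for inhibition of protein deacetylase HDAC6 (Homo sapiens), read by fluorescence, with a stated time of 1 h, tested at 100 nM (on this read-out higher numbers stand for more inhibition at the one concentration tested (going by the name of the read-out) and lower numbers for less inhibition), compound 1 gives 71%.
Compound 2, `Cc1cccc(CN2CCC(c3noc(CN(C)c4ncc(C(=O)NO)cn4)n3)CC2)c1`: in this assay compound 2 gives 54%.

Of the two numbers, the value of compound 2 is the lower; compound 1 stands higher by a gap that lies beyond the usual scatter of this measurement. The two compounds differ in several places at once, so the numbers alone say only that much.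

The piece now follows the step from compound 2 to compound 3, `CN(Cc1nc(C2CCN(Cc3ccccc3Cl)CC2)no1)c1ncc(C(=O)NO)cn1`, which has not yet been measured in this assay. The change is 2-chlorophenyl in place of 3-methylphenyl on a saturated chain carbon bound to an amine nitrogen in a ring.

Among the measured compounds shown here, nothing among the measured compounds shows what such an exchange does: no pair differing only in the group on that saturated chain carbon has been measured. With the rest of the molecule untouched, the expected step from compound 2 to compound 3 is small, a number 1 percentage points higher from compound 2 to compound 3 (within the scatter), with no direction that can be read from the data and a size within the scatter.

For compound 3 the estimate is therefore 55%, expected to fall between 35% and 75%.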

Compound 3, a percentage reported as inhibition, at one concentration (the size of the read-out at that concentration, not a potency): 55%
Compound 3: middle estimate and measured number agree at the digits printed; the range from low to high includes it.
By their numbers in this assay, from the lowest: compounds 2 and 3 (each within the scatter of the next); then compound 1.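

In this assay, putting 2-chlorophenyl in place of 3-methylphenyl on a saturated chain carbon bound to an amine nitrogen in a ring gives a number 1 percentage points higher from compound 2 to compound 3 (within the scatter), so the two compounds cannot be told apart on this read-out. Among the compounds shown here, this single pair is the only measured evidence on this position, and it shows that, on this core, the 3-methylbenzyl to 2-chlorobenzyl exchange leaves the percentage inhibition within the scatter at the one concentration tested. No measurement shown bears on why the exchange has so little visible effect.

The exchange alters both the substituent on the phenyl ring and where it sits, so the compounds shown leave open what each of these contributes alone, and a single pair cannot show whether other groups at this position would behave alike. Going by these compounds, it also remains open whether a more different group, such as a carboxylic acid or an amine on the phenyl ring, or a longer chain in place of the benzyl carbon, would give a step beyond the scatter.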